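This account rests on a few compounds, and the source may have more. Where it says the series, first, only, none or still open, it means among the compounds named here.

Working notes on the series. Compound 1 `Cc1nnc(CN(C)C)n1-c1ccc(Cl)cc1C(=O)c1ccccc1` gives 5 mg/kg in a functional assay on the whole organism (strain CF-1) with Mus musculus as the target; on this read-out lower numbers stand for an effect already at smaller amounts and higher numbers for an effect only at larger amounts of compound. Compound 2 `Cc1nnc(CN2CCCC2)n1-c1ccc(Cl)cc1C(=O)c1ccccc1Cl` gives 18 mg/kg in this assay. Compound 3 `CN(C)Cc1nnc(-c2ccncc2)n1-c1ccc(Cl)cc1C(=O)c1ccccc1Cl` returns only a limit in this assay, > 100 mg/kg, so no number stands for it. That limit is the limit of > 100 mg/kg in this assay, at which 1 of the 3 values shown sits, and compound 3 therefore sits at the edge of what the read-out covers rather than at a point inside it. Within the data shown here, no pair of measured compounds differs in a single place, so no measured step is available.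

Compound 4 `Cc1nnc(CN(C)C)n1-c1ccc(Cl)cc1C(=O)c1ccccc1Cl` is not yet measured. The change from compound 3 to compound 4 is methyl in place of pyridin-4-yl on an aromatic carbon. Compound 4 carries the same methyl as compound 1 and compound 2, whose values in this assay are numbers rather than limits, so a step toward lower numbers, well beyond the scatter, is expected for compound 4 and is written as an at least 10-fold lower number from compound 3 to compound 4 (1.00 log units; beyond the scatter). For compound 4 the estimate in this assay is 10 mg/kg, with an expected range from 3 mg/kg to 40 mg/kg.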

Compound 4, dose for half-maximal effect: 3.2 mg/kg
Beside the measured number, compound 4's estimate is 3.1-fold (0.49 log units) above it; the range from low to high includes it.
By their numbers in this assay, from the lowest: compounds 4 and 1 (each within the scatter of the next); then compound 2. At a limit, above all of these: compound 3.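

In this assay, methyl in place of pyridin-4-yl on the aromatic carbon between two ring nitrogen atoms gives an at least 31-fold lower number from compound 3 to compound 4 (1.49 log units; beyond the scatter), and the size of that step is only a bound because compound 3 holds a limit and not a number: the limit of > 100 mg/kg in this assay, at which 1 of the 4 values shown sits.

On the saturated chain carbon, dimethylamino in place of pyrrolidin-1-yl gives a 5.6-fold lower number from compound 2 to compound 4 (0.75 log units; beyond the scatter), so the amine at that place does change the read-out. Chloro in place of hydrogen on an aromatic carbon gives a 1.6-fold lower number from compound 1 to compound 4 (0.19 log units; within the scatter), within the scatter, so this change shows no readable effect here.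

Going by these compounds, it remains open whether ethyl or phenyl on the carbon between two ring nitrogen atoms would stay near compound 4 or move toward the limit of compound 3. On these data alone, it is also open how morpholin-4-yl would compare with dimethylamino and pyrrolidin-1-yl on the chain carbon.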